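The source may report more compounds than this note shows. Statements on the series, on what has been measured and on what is new or still open speak of the compounds shown alone.

In a physicochemical assay for lipophilicity, using the shake flask method (on this read-out higher numbers stand for higher lipophilicity and lower numbers for lower lipophilicity), compound 1 (`COc1cnc(-c2cc(Oc3ccc(S(C)(=O)=O)cc3)cc(OC(C)C)c2)[nH]c1=O`) gives 2.21 and compound 2 (`CCC(CC)Oc1cc(Oc2cnc(C(=O)N(C)C)nc2)cc(-c2nccc(=O)[nH]2)c1`) gives 1.91 on the same read-out, so the two values lie within the usual scatter of each other. Compound 3 (`COC[C@H](C)Oc1cc(Oc2cnc(C(=O)N(C)C)nc2)cc(-c2nccc(=O)[nH]2)c1`) differs from compound 2 by 1-(methoxymethyl)ethyl in place of pentan-3-yl on an oxygen on an aromatic ring in one place, with 1-(methoxymethyl)ethyl in place of pentan-3-yl on an oxygen on an aromatic ring. Within the data shown here, no measured pair shows this change, so the expectation rests on the structure alone. A decrease beyond the scatter is expected in this assay and is estimated as a number 0.81 log units lower from compound 2 to compound 3 (beyond the scatter) on this read-out. Compound 3 is expected at 1.1 with an estimated range from 0.75 to 1.45 on this read-out.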

Compound 3, distribution coefficient: 0.43
Compound 3: the middle estimate sits 0.67 log units above what was measured, outside the stated range (below it).
By their numbers in this assay, from the lowest: compound 3; then compounds 2 and 1 (each within the scatter of the next).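

In this assay, exchanging pentan-3-yl for 1-(methoxymethyl)ethyl gives a large step, a number 1.48 log units lower from compound 2 to compound 3 (beyond the scatter), although both groups hold 5 heavy atoms and the change is one carbon exchanged for one oxygen. This is the first pair shown that differs in one place, and it establishes that this position can move the read-out well beyond the scatter. No evidence at hand accounts for the size of this step. The compounds shown leave open whether the other stereoisomer of 1-(methoxymethyl)ethyl would read alike, and how a 2-hydroxypropyl or 2-aminopropyl group would read in the same place. Going by these compounds, whether the same exchange would give a similar step on the core of compound 1 also stays open.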